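Phenyl in place of methyl on a carbonyl carbon

The compounds below may be only part of what the source reports. "The series", "measured", "known", "first", "only" and "open" are said of these compounds alone.

In a functional assay on A549 cells (Homo sapiens) for inhibition, read by sulforhodamine B assay, with a stated time of 48 h, tested at 50 uM (a lower number here means less inhibition of growth, a higher number more inhibition of growth at the concentration tested), compound 3 (`COc1ccc([C@@H]2C/C(=N/OCc3cn(-c4ccc(NC(C)=O)cc4)nn3)c3cc(CC=C(C)C)c(OC)cc3O2)cc1`) gives 19% and stands lowest of the three measured compounds, with compound 1 (`COc1ccc([C@@H]2C/C(=N/OCc3cn(-c4ccc(O)cc4)nn3)c3cc(CC=C(C)C)c(OC)cc3O2)cc1`) at 52% and compound 2 (`COc1ccc([C@@H]2C/C(=N/OCc3cn(-c4ccc(C(N)=O)cc4)nn3)c3cc(CC=C(C)C)c(OC)cc3O2)cc1`) at 100% in the same test. Compound 4 (`COc1ccc([C@@H]2C/C(=N/OCc3cn(-c4ccc(NC(=O)c5ccccc5)cc4)nn3)c3cc(CC=C(C)C)c(OC)cc3O2)cc1`) has phenyl in place of methyl on a carbonyl carbon, so acetamido becomes benzamido. Going by the values given here, no measured step makes this exact change. The closest evidence is a set of large swaps on an aromatic carbon, namely a number 33 percentage points lower from compound 1 to compound 3 (beyond the scatter) and a number 48 percentage points higher from compound 1 to compound 2 (beyond the scatter) and also a number 81 percentage points lower from compound 2 to compound 3 (beyond the scatter) in the same series. These run both ways, so the direction stays uncertain, though compound 3 at 19% has more room upward than downward. In this assay the expected step is a number 16 percentage points higher from compound 3 to compound 4 (beyond the scatter) with wide uncertainty. For compound 4 the estimate is 35% within an expected range of 10% to 75% overall.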

Compound 4, percent growth inhibition at one concentration: 31%
Compound 4: the middle estimate sits 4 percentage points above what was measured; low and high end bracket the measured number.
By their numbers in this assay, from the lowest: compound 3; then compound 4; then compound 1; then compound 2.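

In this assay phenyl in place of methyl on a carbonyl carbon gives a number 12 percentage points higher from compound 3 to compound 4 (beyond the scatter) and so shows that this position takes a six-membered aromatic ring with only a modest change in the number. Benzamido still falls short of the other two groups, with a number 21 percentage points lower from compound 1 to compound 4 (beyond the scatter) for benzamido in place of hydroxy and a number 69 percentage points lower from compound 2 to compound 4 (beyond the scatter) for benzamido in place of carbamoyl on the aromatic carbon. Nothing available explains these differences.

Open, from the compounds shown here alone, is how an amine or a carboxylic acid would score on that aromatic carbon. Also open, going by these compounds, is whether a longer chain on the carbonyl carbon would behave like phenyl.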